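Replacing the Methoxyphenyl of Compound 3 with Fluorophenyl

The compounds below may be only part of what the source reports. "The series", "measured", "known", "first", "only" and "open" are said of these compounds alone.

Of the compounds shown here, three have been tested in a functional assay on the whole organism (strain Wistar) for inhibition, with Rattus norvegicus as the target, read by paw edema, with stated times of 30 min and 3 h, at a dose of 200 mg/kg by the oral route; a lower number here means less inhibition, a higher number more inhibition at the dose given (going by the name of the read-out). Compound 1 `COc1ccc(-n2c(-c3ccccc3)cc3c2CCCC3)cc1C(=O)O` gives 40%, compound 2 `COc1cccc(-c2cc3c(n2-c2ccc(O)c(C(=O)O)c2)CCCC3)c1` gives 20%, and compound 3 `COc1ccccc1-c1cc2c(n1-c1ccc(O)c(C(=O)O)c1)CCCC2` gives 50%. Within the data shown here, compound 3 has the highest of the three numbers; its lead over compound 1 lies within the scatter, while its lead over compound 2 lies beyond it, as the single measured step shows: a number 30 percentage points higher from compound 2 to compound 3 (beyond the scatter). Compound 4 `O=C(O)c1cc(-n2c(-c3ccc(F)cc3)cc3c2CCCC3)ccc1O` differs from compound 3 in one place: 4-fluorophenyl in place of 2-methoxyphenyl on an aromatic carbon. Among the measured compounds shown here, no measured step involves 4-fluorophenyl, so the one step in hand bears only loosely; it shows that 2-methoxyphenyl in place of 3-methoxyphenyl already shifts the number by a modest amount. A shift of similar size, most likely downward, is therefore expected, a number 15 percentage points lower from compound 3 to compound 4 (beyond the scatter). Compound 4 is estimated at 35%, between 15% and 55%.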

Compound 4, a percentage reported as inhibition, in the whole organism at one dose (the size of the read-out at that dose, not a potency): >= 60%
Compound 4 was reported as a limit; the forecaster's own chance of this, stated with the estimate: 0%; at least 25 percentage points between middle value and limit.
By their numbers in this assay, from the lowest: compound 2; then compounds 1 and 3 (each within the scatter of the next). At a limit, above all of these: compound 4.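

Compound 4 is reported only as a limit: the limit of >= 60% in this assay, at which 1 of the 4 values shown sits. Among these compounds, with 4-fluorophenyl at this position, the change gives a number at least 40 percentage points higher from compound 2 to compound 4 (beyond the scatter), the first large step. Against 2-methoxyphenyl, the same group gives a number at least 10 percentage points higher from compound 3 to compound 4 (that floor lies within the scatter), so a gain over compound 3 is not established, though a methoxyphenyl is clearly not needed here for a high number.

Going by these compounds, how 2-fluorophenyl, 4-chlorophenyl or a 4-aminophenyl at the same position would compare remains open. So does whether the fluorine itself contributes, as opposed to the ring that carries it.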